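A Chloro Step Repeated on a Second Core

The source may hold more compounds than are shown below. What is called first, only, known or untested is meant among the compounds shown, and "the series" means these compounds.

In a functional assay on HepG2 cells (Homo sapiens) for inhibition, read by crystal violet staining, with a stated time of 48 h (a higher number here means a weaker inhibitor, a lower number a stronger inhibitor), the three measured compounds give these values:
Compound 1, `CCn1sc(Cl)cc1=O`, gives 12000 nM.
Compound 2, `CCn1sc(Cl)c(Cl)c1=O`, gives 12000 nM.
Compound 3, `CCCCCCCCCCCCSc1cc(=O)n(CCC(=O)OC)[s+]1[O-]`, reaches only a limit of the assay, > 100000 nM.

From compound 1 to compound 2 a single change is made: chloro in place of hydrogen on an aromatic carbon. The step of no change at the digits printed from compound 1 to compound 2 (within the scatter). Compound 4, `CCCCCCCCCCCCSc1c(Cl)c(=O)n(CCC(=O)OC)[s+]1[O-]`, is not yet measured and differs from compound 3 by chloro in place of hydrogen on an aromatic carbon. This is the same kind of change as that from compound 1 to compound 2, but the surroundings differ: in compound 2 the chloro sits next to the ring atom that bears a chloro group and two ring bonds from the ring atom that bears an ethyl group, whereas in compound 4 it sits next to the ring atom that bears a large group and two ring bonds from the ring atom that bears a 2-(methoxycarbonyl)ethyl group. How the core of compound 3 differs from the core of compound 1 is not broken down here.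

Compound 3 sits at the limit of > 100000 nM in this assay, at which 1 of the 3 values shown sits. Because the step of no change at the digits printed from compound 1 to compound 2 (within the scatter), the added chloro is expected to move compound 4 little. Compound 4 is expected to give 150000 nM. Its expected range runs from 50000 nM to 500000 nM. The expected step is a step that the limit leaves unreadable from compound 3 to compound 4, most likely reported again only as a limit.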

Compound 4, half-maximal inhibitory concentration: > 100000 nM
Compound 4: only a limit was reported (the forecaster's own chance of this, stated with the estimate: 80%); the middle value lies beyond the limit too.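

Compound 3 and compound 4 each reach only a limit of the assay, not a number, so no step between them can be read: the limit of > 100000 nM in this assay, at which 2 of the 4 values shown sit.

The compounds shown leave open whether chloro in place of hydrogen on an aromatic carbon changes anything on the core of compound 3, since its only readable case stays on the core of compound 1.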